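The source may report more compounds than this note shows. Statements on the series, on what has been measured and on what is new or still open speak of the compounds shown alone.

Compound 1 `CCC(CC)n1c(-c2ccc(OCc3c(-c4c(Cl)cccc4Cl)noc3C(C)C)cc2F)nc2ccc(C(=O)O)cc21`: 1.3 nM
Compound 2 `CCn1c(-c2ccc(OCc3c(-c4c(Cl)cccc4Cl)noc3C(C)C)cc2)nc2ccc(C(=O)O)cc21`: 2.31 nM
Compound 3 `CC(C)c1onc(-c2c(Cl)cccc2Cl)c1COc1ccc(-c2nc3ccc(C(=O)O)cc3n2C2CC2)cc1`: 16.5 nM

In an assay on Huh-7 cells for agonist activity at Bile acid receptor (Homo sapiens), read by a luciferase reporter (a lower number here means that less compound is needed, a higher number that more compound is needed for the effect), compound 3 stands highest of the three numbers. The nearest is compound 2, reached by a 7.1-fold higher number from compound 2 to compound 3 (0.85 log units; beyond the scatter); compound 1 lies further off, and compound 1 gives 1.3 nM. Against that, compound 3 gives 16.5 nM. Compound 4 `CC(=O)N1CCC(n2c(-c3ccc(OCc4c(-c5c(Cl)cccc5Cl)noc4C(C)C)cc3)nc3ccc(C(=O)O)cc32)CC1` differs from compound 3 at the same aromatic nitrogen: 1-acetylpiperidin-4-yl in place of cyclopropyl on an aromatic nitrogen. For the measured compounds named here, only one measured step touches this position, a 7.1-fold higher number from compound 2 to compound 3 (0.85 log units; beyond the scatter), which shows that changing the group on this nitrogen can move the number beyond the scatter. Going by the values given here, no measured step shows a group as large as the one that enters, so the direction is open; the estimated step of a 1.2-fold higher number from compound 3 to compound 4 (0.08 log units; within the scatter) is a small one. Compound 4 is expected at 20 nM, with a range from 5 nM to 80 nM.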

Compound 4, half-maximal effective concentration: 1430 nM
Beside the measured number, compound 4's estimate is 72-fold (1.85 log units) below it; measured number outside the range, above it.
By their numbers in this assay, from the lowest: compounds 1 and 2 (each within the scatter of the next); then compound 3; then compound 4.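

Putting 1-acetylpiperidin-4-yl on the aromatic nitrogen gives an 87-fold higher number from compound 3 to compound 4 (1.94 log units; beyond the scatter) in this assay, and a 620-fold higher number from compound 2 to compound 4 (2.79 log units; beyond the scatter). For the compounds shown here, both steps are far larger than a 7.1-fold higher number from compound 2 to compound 3 (0.85 log units; beyond the scatter), so this nitrogen can move the number much further than the earlier compounds showed, and not every group is accepted alike here. Nothing available explains this rise. Going by these compounds, it remains open whether the ring or the acetyl group matters more. A piperidine with a free amine, a cyclohexyl ring or a longer carbon chain on this nitrogen could separate the two.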